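A Fluorine Step Carried From One Core to Another

The compounds below may be only part of what the source reports. "The series", "measured", "known", "first", "only" and "open" are said of these compounds alone.

Of the compounds shown here, three have been tested in a functional assay on the whole organism with Scenedesmus acutus as the target, with a stated time of 20 h; a higher number here means a weaker inhibitor, a lower number a stronger inhibitor. Compound 1 `S=c1n(-c2ccc(Cl)cc2)c(=S)n2n1CCCC2` gives 50.1 nM, and compound 2 `Fc1cc(Cl)ccc1-n1c(=S)n2n(c1=S)CCCC2` gives 27.5 nM. The only difference between the two is fluoro in place of hydrogen on an aromatic carbon, and that change produced a 1.8-fold lower number from compound 1 to compound 2 (0.26 log units; within the scatter).

Compound 3 `S=c1s/c(=N\c2ccc(Cl)cc2)n2n1CCCC2` is built from the same atoms as compound 1, joined differently; the difference between the two cores is not broken down here. In this assay compound 3 gives 550 nM, a number far above that of compound 1 and above that of compound 2, so compound 3 is the weakest inhibitor of the three measured.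

Compound 4 `Fc1cc(Cl)ccc1/N=c1\sc(=S)n2n1CCCC2` has not yet been measured. It is related to compound 3 by fluoro in place of hydrogen on an aromatic carbon, the same change that separates compound 1 from compound 2, made at the same kind of place.

Because that change gave only a 1.8-fold lower number from compound 1 to compound 2 (0.26 log units; within the scatter) on the first core, compound 4 is expected to sit close to compound 3 rather than to move far from it. The expected step is a 1.7-fold lower number from compound 3 to compound 4 (0.24 log units; within the scatter), which stays within what repeated measurements would show. Compound 4 is therefore estimated at 320 nM in this assay, most likely between 130 nM and 900 nM.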

Compound 4, half-maximal inhibitory concentration: 91.2 nM
For compound 4 the middle estimate is 3.5-fold (0.55 log units) above the measured one; measured number outside the range, below it.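

In this assay, fluoro in place of hydrogen on an aromatic carbon gives a 6.0-fold lower number from compound 3 to compound 4 (0.78 log units; beyond the scatter), a step beyond the usual scatter, whereas on the core of compound 1 the same change gives a 1.8-fold lower number from compound 1 to compound 2 (0.26 log units; within the scatter), which stays within it. Set side by side, the two steps do not match in size, so the effect of this change on the core of compound 1 did not predict its size on the core of compound 3: the same change on two cores in this assay, a 1.8-fold lower number (0.26 log units; within the scatter) from compound 1 to compound 2 and a 6.0-fold lower number (0.78 log units; beyond the scatter) from compound 3 to compound 4, 3.3-fold (0.52 log units) apart, beyond the scatter of two such steps

Going by these compounds alone, this shows that a step measured on one core cannot simply be copied to the other, but with only one pair on each core it does not show why the two cores differ or how the change would behave on any further core.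

From the compounds shown here alone, it remains open whether a methyl group or a methoxy group in the place taken by fluoro would also give steps of different size on the two cores. Going by these compounds, it is equally open whether the difference would persist with a trifluoromethyl group in place of the chloro group.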